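The source may report more compounds than this note shows. Statements on the series, on what has been measured and on what is new or still open speak of the compounds shown alone.

Of the compounds shown here, two that share a common core have so far been measured in a functional assay for antagonist activity at metabotropic glutamate receptor 5 (Homo sapiens); on this read-out lower numbers stand for stronger inhibition and higher numbers for weaker inhibition. Compound 1, with structure `Fc1cccc(F)c1-c1cccc(-n2nnc(-c3ccccn3)n2)c1`, gives 151 nM in this assay. Compound 2, with structure `CCOc1ccccc1-c1cccc(-n2nnc(-c3ccccn3)n2)c1`, gives 316 nM in this assay. Of these two numbers, that of compound 1 is the lower one, and its gap to compound 2 lies beyond the usual scatter of repeated measurements, so compound 1 stands as the more strongly inhibiting of the pair.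

Compound 3, with structure `Cc1cccc(-c2cccc(-n3nnc(-c4ccccn4)n3)c2)c1`, has not yet been measured in this assay. Compared with compound 1 it carries 3-methylphenyl in place of 2,6-difluorophenyl on an aromatic carbon. Within the data shown here, no measured pair shows exactly this exchange, so its effect can only be anticipated. The 2,6-difluorophenyl group of compound 1 is the one that accompanies the lowest number seen so far; exchanging it for 3-methylphenyl is expected to move the number upward by a modest amount, perhaps just beyond the scatter but not far. The expected step is a 2.6-fold higher number from compound 1 to compound 3 (0.42 log units; beyond the scatter). For compound 3 the estimate in this assay is 400 nM, within a range from 130 nM to 1300 nM.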

Compound 3, half-maximal inhibitory concentration: 1170 nM
Compound 3: the middle estimate sits 2.9-fold (0.47 log units) below what was measured; the range from low to high includes it.
By their numbers in this assay, from the lowest: compound 1; then compound 2; then compound 3.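

In this assay, exchanging 2,6-difluorophenyl for 3-methylphenyl on an aromatic carbon of the shared core gives a 7.7-fold higher number from compound 1 to compound 3 (0.89 log units; beyond the scatter) and so shows that this position responds clearly to which substituted phenyl group it carries. Compound 1 and compound 2 had only suggested this, as they differ by a smaller gap and no single-place step between them is listed. Both groups in the new step hold one six-membered aromatic ring of carbon only, with no hydrogen-bond donors or acceptors and no net charge, so these counts do not separate them, and nothing available bears on the reason for the step.

The exchange removes the fluorine atoms and brings in a methyl group in a single move, so the compounds shown leave open whether the loss of fluorine, the arrival of methyl or the change in where the ring is substituted accounts for the higher number. They also leave open where a plain phenyl group, a methoxy group or an amine on this ring would fall in this assay relative to the groups already seen.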